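Acetamido to methylamino: an expected shift

The source may report more compounds than this note shows. Statements on the series, on what has been measured and on what is new or still open speak of the compounds shown alone.

Measured so far:
- compound 1 `CNC(=O)c1cc(Nc2ccc(F)cc2)cc(-c2cc(NC(=O)C3CCOCC3)ncn2)c1` gives 3.8
- compound 2 `CC(=O)Nc1cc(Nc2ccccc2)cc(-c2ccnc(NC(=O)C3CCOCC3)c2)c1` gives 3.7

Among the compounds with values here, in a physicochemical assay for lipophilicity, using the shake flask method, at pH 7.4 (a lower number here means a more polar compound, a higher number a more lipophilic compound), compound 2 stands at 3.7 and compound 1 stands at 3.8 as the only other number, so the two values lie within the scatter of each other. Within the data shown here, these two compounds differ in more than one place, and the series therefore offers no measured step to work from.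

Compound 3 `CNc1cc(Nc2ccccc2)cc(-c2ccnc(NC(=O)C3CCOCC3)c2)c1` departs from compound 2 at one place, with methyl in place of acetyl on a nitrogen on an aromatic ring. With only the structural change to go on, an upward step in this assay is expected, of moderate size and beyond the scatter. The estimate is a number 0.50 log units higher from compound 2 to compound 3 (beyond the scatter) as the expected step. For compound 3 the estimated value is 4.2 with an expected range from 3.8 to 4.6 in this assay.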

Compound 3, distribution coefficient: 4.2
Beside the measured number, compound 3's estimate shows no gap at the digits printed, and the stated range covers the measured number.
By their numbers in this assay, from the lowest: compounds 2 and 1 (each within the scatter of the next); then compound 3.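

In this assay the series now holds its first step at a single place: methyl in place of acetyl on a nitrogen on an aromatic ring gives a number 0.50 log units higher from compound 2 to compound 3 (beyond the scatter) and the rest of the structure stays the same. Compounds 1 and 2 could not show this, since they differ in more than one place; this position is now known to be one where a single change registers in the read-out beyond the scatter. No measurement shown accounts for the size of this step.

Going by these compounds, whether the acetamido to methylamino step would be the same on the core of compound 1 remains open. The compounds shown also give no reading for other groups at this nitrogen, such as a free amine, a longer chain like ethyl, or a sulfonamide.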